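Amide substituent variation on the shared core

The source may report more compounds than this note shows. Statements on the series, on what has been measured and on what is new or still open speak of the compounds shown alone.

Measured compounds:
compound 1 `COc1ccc2c(=O)c(/C=C/C(=O)Nc3cccc(Cl)c3)coc2c1`: in a functional assay on Huh-7 cells (Homo sapiens) for inhibition, read by MTT assay, with a stated time of 48 h (on this read-out lower numbers stand for stronger inhibition and higher numbers for weaker inhibition), compound 1 gives > 100000 nM, which is a limit of the assay and not a number.
compound 2 `O=C(/C=C/c1coc2cc(O)ccc2c1=O)NCc1ccccc1`: in this assay compound 2 gives 4690 nM.
compound 3 `COc1ccc2c(=O)c(/C=C/C(=O)NCc3ccccc3)coc2c1`: in this assay compound 3 gives 13600 nM.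

Compound 3 stands highest of the two numbers, with compound 2 nearest; the step of a 2.9-fold higher number from compound 2 to compound 3 (0.46 log units; beyond the scatter) comes from methyl in place of hydrogen on an oxygen on an aromatic ring. The step of an at least 7.3-fold lower number from compound 1 to compound 3 (0.86 log units; beyond the scatter) comes from benzyl in place of 3-chlorophenyl on the amide-type nitrogen, and its size is only a lower bound since compound 1 sits at the limit of > 100000 nM in this assay, at which 1 of the 3 values shown sits.

Compound 4 `COc1ccc2c(=O)c(/C=C/C(=O)Nc3ccccc3Cl)coc2c1` is not yet measured. It differs from compound 3 by 2-chlorophenyl in place of benzyl on an amide-type nitrogen. This change runs opposite to the step from compound 1 to compound 3, with the chlorine placed differently on the ring. Within the data shown here, only that one step bears on it, so a move back toward a higher number in this assay is expected, of at least modest size, with a fair chance that only a limit is reported. The estimated step is a 5.9-fold higher number from compound 3 to compound 4 (0.77 log units; beyond the scatter). For compound 4 the estimate is 80000 nM, with a range from 25000 nM to 250000 nM.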

Compound 4, half-maximal inhibitory concentration: 58400 nM
Compound 4: the middle estimate sits 1.4-fold (0.14 log units) above what was measured, within the range that was stated.
By their numbers in this assay, from the lowest: compound 2; then compound 3; then compound 4. At a limit, above all of these: compound 1.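

Replacing benzyl with 2-chlorophenyl on the amide-type nitrogen gives a 4.3-fold higher number from compound 3 to compound 4 (0.63 log units; beyond the scatter) in this assay, so a change of this kind at this position now has a measured size and not only a bound. The change from 3-chlorophenyl to 2-chlorophenyl gives an at least 1.7-fold lower number from compound 1 to compound 4 (0.23 log units; that floor lies within the scatter), which is only a floor, so these two compounds cannot be placed in order. The value of compound 1 is a limit and not a number: the limit of > 100000 nM in this assay, at which 1 of the 4 values shown sits.

Still open, as far as these compounds go, is whether the step from benzyl belongs to the chlorine or to the change from benzyl to a ring carried on the nitrogen without its carbon link; an unsubstituted phenyl or a 2-chlorobenzyl group on that nitrogen would separate the two. Also open, from the compounds shown here alone, is whether the hydroxyl form seen in compound 2 would shift the 2-chlorophenyl amide as it does the benzyl amide.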